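This account rests on a few compounds, and the source may have more. Where it says the series, first, only, none or still open, it means among the compounds named here.

Two compounds of the series have numbers in a functional assay on SGC-7901 cells (Homo sapiens) for cytotoxicity, read by MTT assay, with a stated time of 48 h; on this read-out higher numbers stand for weaker inhibition and lower numbers for stronger inhibition. Compound 1 `CCN(CC)c1ccc2cc(C(=O)c3ccc(N4CCN(C(=O)COc5ccc(Cl)cc5Cl)CC4)cc3)oc2c1` gives 6170 nM. Compound 2 `CCN(CC)c1ccc2cc(C(=O)c3ccc(N4CCN(S(=O)(=O)c5ccc(C(F)(F)F)cc5)CC4)cc3)oc2c1` gives 170 nM, the lower of the two numbers, separated from compound 1 by a gap well beyond the scatter. Compound 3 `CCN(CC)c1ccc2cc(C(=O)c3ccc(N4CCN(S(C)(=O)=O)CC4)cc3)oc2c1` is not yet measured; it differs from compound 2 by methyl in place of 4-(trifluoromethyl)phenyl on a sulfonyl sulfur. Going by the values given here, no measured pair isolates this change, so the direction must be guessed. The expected step of a 12-fold higher number from compound 2 to compound 3 (1.07 log units; beyond the scatter) is toward weaker inhibition, likely beyond the scatter. Compound 3 is estimated at 2000 nM, with a range from 400 nM to 10000 nM.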

Compound 3, half-maximal inhibitory concentration: > 40000 nM
Compound 3 was reported as a limit (the forecaster's own chance of this, stated with the estimate: 10%); middle value at least 20-fold (1.30 log units) from the limit.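

On the sulfonyl sulfur, the change to methyl from 4-(trifluoromethyl)phenyl costs nearly all inhibition in this assay: an at least 230-fold higher number from compound 2 to compound 3 (2.37 log units; beyond the scatter). Compound 3 gives > 40000 nM, which is a limit and not a number, so both of its steps are lower bounds. A sulfonyl group alone does not preserve inhibition, since methylsulfonyl in place of ((2,4-dichlorophenoxy)methyl)carbonyl on an amine nitrogen in a ring gives an at least 6.4-fold higher number from compound 1 to compound 3 (0.81 log units; beyond the scatter).

The compounds shown do not separate the contribution of the aromatic ring from that of its trifluoromethyl group. Unsubstituted phenyl or a longer alkyl chain on the sulfonyl sulfur would address this.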